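This account rests on a few compounds, and the source may have more. Where it says the series, first, only, none or still open, it means among the compounds named here.

Measured so far in a physicochemical assay for solubility, read by HPLC, in phosphate buffer, measured as kinetic solubility, at pH 6.5; a lower number here means a less soluble compound, a higher number a more soluble compound
Compound 1 `COc1ccc(C(F)(F)F)cc1CN(C1CC1)C(c1cccnc1)c1nnnn1-c1ccccc1C` gives 1.6 ug/mL
Compound 2 `Cc1ccccc1-n1nnnc1C(c1cccnc1)N(Cc1cccc(C(F)(F)F)c1)C1CC1` gives 1.5 ug/mL

Only these two numbers exist so far, and compound 2 (1.5 ug/mL) sits level with compound 1 within the scatter of repeated measurements. Compound 3 `Cc1ccccc1-n1nnnc1C(c1cncnc1)N(Cc1cccc(C(F)(F)F)c1)C1CC1` keeps the rest of compound 2 and changes one ring (pyrimidin-5-yl in place of pyridin-3-yl on a saturated chain carbon bound to an amine nitrogen and an aromatic carbon). In words, pyrimidin-5-yl stands in place of pyridin-3-yl on a saturated chain carbon bound to an amine nitrogen and an aromatic carbon.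

Just one measured step is available (a 1.1-fold lower number from compound 1 to compound 2 (0.03 log units; within the scatter)), in which hydrogen takes the place of methoxy on an aromatic carbon. That step lies within the scatter, but it concerns a different part of the molecule, so it offers little guidance here. Among the measured compounds shown here, no measured pair makes this ring swap, which leaves the direction in this assay uncertain. The expected step is small and upward (a 1.7-fold higher number from compound 2 to compound 3 (0.22 log units; within the scatter)), and it could still fall within the scatter. For compound 3 the estimated value is 2.5 ug/mL (expected range 1 ug/mL to 8 ug/mL).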

Compound 3, solubility: 1.5 ug/mL
For compound 3 the middle estimate is 1.7-fold (0.22 log units) above the measured one; the measured number falls inside the stated range.
By their numbers in this assay, from the lowest: compounds 2, 3 and 1 (each within the scatter of the next).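

Placing pyrimidin-5-yl in place of pyridin-3-yl on a saturated chain carbon bound to an amine nitrogen and an aromatic carbon gives, in this assay, no change at the digits printed from compound 2 to compound 3 (within the scatter) for this change. Among the compounds shown here, this is the first measured view of this position, as the earlier pair differed only by hydrogen in place of methoxy elsewhere in the molecule. Here, a ring with 2 hetero atoms and 2 hydrogen-bond acceptors reads the same as one with 1 hetero atom and 1 hydrogen-bond acceptor, so in this series the added ring nitrogen leaves the reading within the scatter, and nothing measured alongside it bears on why.

The compounds shown leave open whether a group of a different kind at this place, such as a pyridine ring carrying an amine or a carboxylic acid, would move the number beyond the scatter. From the compounds shown here alone, it also remains open whether the same ring swap would read the same with the methoxy of compound 1 kept in the molecule.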